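Bromo for Fluoro: Compound 4 Expected From Compound 3

The compounds below may be only part of what the source reports. "The series", "measured", "known", "first", "only" and "open" are said of these compounds alone.

Compound 3 `CO[C@@H]1[C@H](N(C)c2ncc(-c3c[nH]c4ccc(F)cc34)s2)C[C@H]2O[C@]1(C)n1c3ccccc3c3c4c(c5c6cc(Br)ccc6n2c5c31)C(=O)NC4` stands at the upper edge of what an ADME assay on PBMC cells (Homo sapiens) for cytotoxicity, read by CellTiter-Glo, with a stated time of 72 h (on this read-out higher numbers stand for weaker inhibition and lower numbers for stronger inhibition), can report. In this assay compound 3 gives > 10000 nM, which is a limit of the assay and not a number. Its two measured relatives sit at the same point. Compound 1 `CO[C@@H]1[C@H](N(C)c2ncc(-c3c[nH]c4ccc(Br)cc34)s2)C[C@H]2O[C@]1(C)n1c3ccccc3c3c4c(c5c6ccccc6n2c5c31)C(=O)NC4` gives > 10000 nM in this assay, again a limit. Compound 2 `CO[C@@H]1[C@H](N(C)c2ncc(-c3c[nH]c4ccccc34)s2)C[C@H]2O[C@]1(C)n1c3ccccc3c3c4c(c5c6cc(Br)ccc6n2c5c31)C(=O)NC4` gives > 10000 nM in this assay, likewise a limit. Within the data shown here, the only measured step leading into compound 3, a step that the two limits leave unreadable from compound 2 to compound 3, has no readable size because of the limit of > 10000 nM in this assay, at which 3 of the 3 values shown sit.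

Compound 4 `CO[C@@H]1[C@H](N(C)c2ncc(-c3c[nH]c4ccc(Br)cc34)s2)C[C@H]2O[C@]1(C)n1c3ccccc3c3c4c(c5c6cc(Br)ccc6n2c5c31)C(=O)NC4` is the next member and has not yet been measured in this assay. It differs from compound 3 by bromo in place of fluoro on an aromatic carbon; in words, bromo in place of fluoro on an aromatic carbon, the change reading 5-fluoro-1H-indol-3-yl to 5-bromo-1H-indol-3-yl when cut one bond further out. Among the measured compounds shown here, no measured step covers this exchange, and the step into compound 3 is itself unreadable. What the numbers do show is that compound 1, which already carries 5-bromo-1H-indol-3-yl, sits at the limit, as do compound 2 and compound 3. Compound 4 is therefore expected to show no step beyond the scatter, a step that the limit leaves unreadable from compound 3 to compound 4, and to give an estimated 15000 nM with a range from 8000 nM to 40000 nM, most likely reported only as a limit.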

Compound 4, half-maximal inhibitory concentration: > 10000 nM
Compound 4: only a limit was reported; the forecaster's own chance of this, stated with the estimate: 85%; the middle value is on the limit's open side.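

No step from compound 1, compound 2 or compound 3 to compound 4 can be read in this assay, because all of these results are limits and not numbers: the limit of > 10000 nM in this assay, at which 4 of the 4 values shown sit.

The compounds shown leave open what number each would give, and so whether bromo, fluoro or hydrogen in these places makes any difference in this assay.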